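Removing chloro from the 4-chlorophenyl group of compound 2

The source may hold more compounds than are shown below. What is called first, only, known or untested is meant among the compounds shown, and "the series" means these compounds.

In a functional assay on U-87MG ATCC cells for antiproliferative activity against U-87 MG (Homo sapiens), read by MTT assay, with a stated time of 48 h (on this read-out higher numbers stand for weaker inhibition and lower numbers for stronger inhibition), compound 1 (`COc1cccc(-c2nc(SCC(=O)c3sc(-c4ccccc4)nc3C)[nH]c(=O)c2C#N)c1`) reads 59700 nM and compound 2 (`Cc1nc(-c2ccc(Cl)cc2)sc1C(=O)CSc1nc(-c2ccc(Cl)c(Cl)c2)c(C#N)c(=O)[nH]1`) reads 83900 nM so compound 2 stands within the scatter of compound 1. Compound 3 (`Cc1nc(-c2ccccc2)sc1C(=O)CSc1nc(-c2ccc(Cl)c(Cl)c2)c(C#N)c(=O)[nH]1`) has hydrogen in place of chloro on an aromatic carbon so that 4-chlorophenyl becomes phenyl. Among the measured compounds shown here, no measured pair isolates this change. The expected step of a 1.1-fold lower number from compound 2 to compound 3 (0.05 log units; within the scatter) is none beyond the scatter, with no direction favoured. For compound 3 the estimated value in this assay is 75000 nM with an expected range from 35000 nM to 160000 nM on this read-out.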

Compound 3, half-maximal inhibitory concentration: 65000 nM
Beside the measured number, compound 3's estimate is 1.2-fold (0.06 log units) above it; measured number inside the range.
By their numbers in this assay, from the lowest: compounds 1, 3 and 2 (each within the scatter of the next).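

In this assay the chloro on the 4-chlorophenyl group can give way to hydrogen with a 1.3-fold lower number from compound 2 to compound 3 (0.11 log units; within the scatter), so this position shows no measurable dependence on that chloro. On the other aryl group, 3,4-dichlorophenyl in place of 3-methoxyphenyl gives a 1.1-fold higher number from compound 1 to compound 3 (0.04 log units; within the scatter), so that swap is not separated from the scatter either. Nothing measured here offers a reason for either result. Open, as far as these compounds go, is whether an amine or a carboxylic acid at the position of the chloro would move the number beyond the scatter.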